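The compounds below may be only part of what the source reports. "The series", "measured", "known", "first", "only" and "open" are said of these compounds alone.

Measured in an ADME assay on L02 cells (Homo sapiens) for cytotoxicity, read by MTT assay, with a stated time of 72 h; on this read-out higher numbers stand for weaker inhibition and lower numbers for stronger inhibition:
Compound 1, `O=C(CCC(=O)OCCCCCCSc1ccc([N+](=O)[O-])c2nonc12)Nc1ccccc1F`, gives 4270 nM.
Compound 2, `O=C(CCC(=O)OCCCCCCSc1ccc([N+](=O)[O-])c2nonc12)Nc1ccc(F)cc1`, gives 6460 nM.
Compound 3, `COc1ccc(NC(=O)CCC(=O)OCCCCCCSc2ccc([N+](=O)[O-])c3nonc23)cc1`, gives 8170 nM.

Compound 1 gives the lowest of the three numbers in this assay, but its neighbours stand close: the step is a 1.5-fold higher number from compound 1 to compound 2 (0.18 log units; within the scatter) and a 1.9-fold higher number from compound 1 to compound 3 (0.28 log units; within the scatter), both within the scatter, so no order among the three can be claimed. All three share one core and differ only in the group carried on the amide-type nitrogen.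

Compound 4, `CN(C)CCNC(=O)CCC(=O)OCCCCCCSc1ccc([N+](=O)[O-])c2nonc12`, is the next case. Against compound 1 the change is 2-(dimethylamino)ethyl in place of 2-fluorophenyl on an amide-type nitrogen. The measured steps bear on it only loosely: they exchange one ring-bearing group for another on the same nitrogen, and each of them, a 1.5-fold higher number from compound 1 to compound 2 (0.18 log units; within the scatter), a 1.9-fold higher number from compound 1 to compound 3 (0.28 log units; within the scatter) and a 1.3-fold higher number from compound 2 to compound 3 (0.10 log units; within the scatter), stays within the scatter. From the compounds shown here alone, nothing measured here swaps the ring for a chain of the kind that enters in compound 4, so that part is untested. What is shown is that changing the group on this nitrogen has so far moved this assay little. The expectation is therefore a step of a 1.4-fold higher number from compound 1 to compound 4 (0.15 log units; within the scatter), not beyond the scatter, with the estimate for compound 4 placed at 6000 nM and a range from 2500 nM to 15000 nM.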

Compound 4, half-maximal inhibitory concentration: 5980 nM
Estimate against measurement, compound 4: 1.0-fold (0.00 log units) above; the measured number falls inside the stated range.
By their numbers in this assay, from the lowest: compounds 1, 4, 2 and 3 (each within the scatter of the next).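

Up to compound 3, the steps in this assay only exchanged one ring-bearing group for another on the amide-type nitrogen, whereas compound 4 carries no ring there, only the open 2-(dimethylamino)ethyl chain. Even so, the step is a 1.4-fold higher number from compound 1 to compound 4 (0.15 log units; within the scatter) and the comparisons with the other two ring-bearing compounds give a 1.4-fold lower number from compound 3 to compound 4 (0.14 log units; within the scatter) and a 1.1-fold lower number from compound 2 to compound 4 (0.03 log units; within the scatter) so all three lie within the scatter, and among these four compounds an aromatic ring on this nitrogen is not required for a number of this size. No measurement shown here explains this lack of separation.

Still open, from the compounds shown here alone, is how a plain ethyl group, which holds no amine, would compare on this nitrogen, a case that would help separate the loss of the ring from the entry of the dimethylamino group. Also open, going by these compounds, is whether a carboxylic acid in place of that dimethylamino group, or a longer chain carrying the same amine, would stay as close to these compounds in this assay as compound 4 does.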